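A few compounds are considered here, and "the series" means these few. Any claim that something is new, unique, unknown or untested is made for them only; others in the source may bear on it.

Measured so far:
- Compound 1, `COc1cccc(/C=C2\CCC/C(=C\c3ccc(O)c(Cl)c3)C2=O)c1OC`: 14300 nM
- Compound 2, `COc1ccc(/C=C2\CCC/C(=C\c3ccccc3Cl)C2=O)cc1OC`: 6800 nM

Both compounds were tested in a functional assay on HT-1080 cells (Homo sapiens) for cytotoxicity, read by MTT assay, with a stated time of 72 h; on this read-out higher numbers stand for weaker inhibition and lower numbers for stronger inhibition. In this assay compound 1 gives 14300 nM, while compound 2 gives 6800 nM. Among the compounds with values here, of the two numbers, the one for compound 2 is the lower, and the gap between it and compound 1 is larger than the usual scatter of repeated measurements, so compound 2 stands as the stronger of the two on this read-out.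

The next compound, compound 3, `COc1ccc(/C=C2\CCC/C(=C\c3cc(Cl)cc(Cl)c3)C2=O)cc1OC`, shares its core with compound 2 and differs in one group: 3,5-dichlorophenyl in place of 2-chlorophenyl on a double-bonded chain carbon bound to a double-bonded ring carbon. Within the data shown here, there is no measured pair in this set that shows what such a change does, so the expectation rests on compound 2 alone and on the general spread of the two numbers seen so far. Because compound 2 gives 6800 nM, compound 3 is expected to land near it, with no step beyond the scatter in either direction; the expected step is a 1.0-fold lower number from compound 2 to compound 3 (0.02 log units; within the scatter). Compound 3 is therefore estimated at 6500 nM, with a likely range from 2200 nM to 20000 nM.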

Compound 3, half-maximal inhibitory concentration: 3000 nM
Beside the measured number, compound 3's estimate is 2.2-fold (0.34 log units) above it; measured number inside the range.
By their numbers in this assay, from the lowest: compound 3; then compound 2; then compound 1.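

Within the data shown here, this is the first pair in the set that differs in one place only, so it gives the first direct view of what this position can do: in this assay, replacing 2-chlorophenyl with 3,5-dichlorophenyl on a double-bonded chain carbon bound to a double-bonded ring carbon gives a 2.3-fold lower number from compound 2 to compound 3 (0.36 log units; beyond the scatter), a modest gain in strength on this read-out. The number therefore responds to what sits at this position, even though the rest of the molecule stays the same and the entering group differs from the leaving one by only a single extra chlorine atom along with a different chlorine pattern. Nothing available here explains why the number moves in this direction.

The step combines two changes, the count of chlorine atoms and their placement on the ring, and a 3-chlorophenyl or an unsubstituted phenyl group at this position would be needed to tell these apart. As far as these compounds go, it also remains open whether a bromine atom, a nitrile or an amine on this ring would go the same way, and whether the same change would hold on the core of compound 1.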